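Bromo to hydroxy on a phenyl group at high inhibition

This account rests on a few compounds, and the source may have more. Where it says the series, first, only, none or still open, it means among the compounds named here.

Of the compounds shown here, three have been measured in a functional assay on T47D cells (Homo sapiens) for inhibition, read by CCK-8 assay, with a stated time of 72 h, tested at 10 uM (a higher number here means more inhibition of growth at the concentration tested, a lower number less inhibition of growth), and two of them sit close together. Compound 3 (`CN(C)C(=O)c1cc2cnc(Nc3ccc(NC(=O)C4(C(=O)Nc5ccc(Br)cc5)CC4)cc3)nc2n1C1CCCC1`) gives 94.3% and compound 2 (`CN(C)C(=O)c1cc2cnc(Nc3ccc(NC(=O)C4(C(=O)Nc5cccc(Cl)c5)CC4)cc3)nc2n1C1CCCC1`) gives 92.6% in this test. Exchanging one halogen-bearing phenyl group for the other amounts to a number 1.7 percentage points higher from compound 2 to compound 3 (within the scatter), so the two cannot be told apart. Compound 1 (`CN(C)C(=O)c1cc2cnc(Nc3ccc(N)cn3)nc2n1C1CCCC1`), which lacks the arm carrying that phenyl group, stands clearly lower at 61.1%.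

Compound 4 (`CN(C)C(=O)c1cc2cnc(Nc3ccc(NC(=O)C4(C(=O)Nc5ccc(O)cc5)CC4)cc3)nc2n1C1CCCC1`) alters compound 3 at a single point: hydroxy in place of bromo on an aromatic carbon. This puts hydroxy in place of bromo on an aromatic carbon, para to a large group. For the measured compounds named here, the halogen exchange is the only measured step on this phenyl group, and no measured compound carries a hydroxy there, so the evidence is thin. That flat step gives no reason to expect a collapse. Still, hydroxy is a different kind of group from a halogen, and values this near the top of the scale have more room to fall than to rise. The expected change is a modest fall, a number 8.3 percentage points lower from compound 3 to compound 4 (within the scatter), and this estimate is uncertain. For compound 4 the estimated value is 86%, with an expected range from 70% to 96%.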

Compound 4, percent growth inhibition at one concentration: 95.8%
Compound 4: the middle estimate sits 9.8 percentage points below what was measured, within the range that was stated.
By their numbers in this assay, from the lowest: compound 1; then compounds 2, 3 and 4 (each within the scatter of the next).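

In this assay, hydroxy in place of bromo on an aromatic carbon gives a number 1.5 percentage points higher from compound 3 to compound 4 (within the scatter), and 4-hydroxyphenyl in place of 3-chlorophenyl gives a number 3.2 percentage points higher from compound 2 to compound 4 (within the scatter). For the compounds shown here, until now, this phenyl group had been seen only with a halogen on it, so these steps add something new: in this test, a halogen is not needed there for the number to stay this high, even though hydroxy brings a hydrogen-bond donor and acceptor that bromo lacks. Nothing measured here explains why these compounds read alike.

All three numbers lie close to the top of the scale at a single tested concentration, so this read-out leaves open whether the compounds would separate at lower concentrations, where a real difference between bromo, chloro and hydroxy could appear. It also leaves open how far this freedom extends: whether an amine, a carboxylic acid or a methoxy group at the same place would keep the number this high, and whether a longer chain in place of the whole phenyl group would do the same.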